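A few compounds are considered here, and "the series" means these few. Any claim that something is new, unique, unknown or untested is made for them only; others in the source may bear on it.

Measured compounds:

Compound 1, `C=CCONC(=O)Cn1cc(C(=O)NCC(=O)N[C@@H](CC(C)C)C(=O)O)c2ccccc21`. In a functional assay on MRC5 cells (Homo sapiens) for inhibition, read by microscopy and resazurin assay, with a stated time of 72 h (a lower number here means a stronger inhibitor, a higher number a weaker inhibitor), compound 1 gives > 128000 nM, a limit of the assay rather than a number.
Compound 2, `C=CCONC(=O)Cn1cc(C(=O)N[C@@H](C)C(=O)N[C@H](C(=O)O)C(C)C)c2ccccc21`. In this assay compound 2 gives > 128000 nM, again a limit.
Compound 3, `C=CCONC(=O)Cn1cc(C(=O)N[C@@H](C)C(=O)N[C@@H](CC(C)C)C(=O)O)c2ccccc21`. In this assay compound 3 gives > 128000 nM, also a limit.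

Compound 3 therefore stands nowhere in particular among the three: all values shown sit at the limit of > 128000 nM in this assay, at which 3 of the 3 values shown sit, and no order among compound 1, compound 2 and compound 3 can be read. The two measured steps that reach compound 3, a step that the two limits leave unreadable from compound 1 to compound 3 and a step that the two limits leave unreadable from compound 2 to compound 3, are unreadable in size and direction for the same reason.

Compound 4, `CC(C)C[C@H](NC(=O)[C@H](C)NC(=O)c1cn(CC(=O)NOCc2ccccc2)c2ccccc12)C(=O)O`, is not yet measured. It differs from compound 3 by phenyl in place of vinyl on a saturated chain carbon bound to an oxygen on an unsaturated carbon; cut one bond further out, the change reads allyl to benzyl, allyloxy to benzyloxy, (allyloxy)amino to (benzyloxy)amino. Within the data shown here, no measured step touches this part of the molecule, and the two that exist give no readable size. There is thus no basis for expecting a step in this assay beyond the scatter in either direction; the expectation is that compound 4 is most likely reported at the same limit. The estimated step is a number no higher from compound 3 to compound 4 (the limit leaves the size open). For compound 4 the estimate is 128000 nM, expected between 40000 nM and 400000 nM.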

Compound 4, half-maximal inhibitory concentration: > 128000 nM
Compound 4: only a limit was reported; the forecaster's own chance of this, stated with the estimate: 80%; the middle value sits exactly at the limit.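

In this assay compound 4 gives > 128000 nM, a limit and not a number, and no step from compound 3 to compound 4 can be read, since all the compounds shown share one limit: the limit of > 128000 nM in this assay, at which 4 of the 4 values shown sit.

The compounds shown leave open how strongly any of them inhibits in this assay, and so whether phenyl in place of vinyl changes anything there.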